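Replacing tert-butylamino with a carbamoylmethyl methylamino group

The compounds below may be only part of what the source reports. "The series", "measured", "known", "first", "only" and "open" are said of these compounds alone.

Compound 1, `Cc1c(Sc2ccc(Cl)cc2)c(=O)on1C(=O)N1CCCCC1`, in an assay (strain Wistar) for inhibition of Hormone-sensitive lipase (Rattus norvegicus), read by spectrophotometry (on this read-out lower numbers stand for stronger inhibition and higher numbers for weaker inhibition), gives 6 nM. Compound 2, `Cc1c(C(C)C)c(=O)on1C(=O)NC(C)(C)C`, in this assay reaches only the assay limit, recorded as > 1000 nM. Compound 3, `Cc1c(C(C)C)c(=O)on1C(=O)Nc1ccccc1`, in this assay likewise sits at the assay limit, recorded as > 1000 nM.

Compound 2 thus stands at the limit of > 1000 nM in this assay, at which 2 of the 3 values shown sit, a limit rather than a number, so its true potency is not pinned down. Compound 4, `Cc1c(C(C)C)c(=O)on1C(=O)N(C)CC(N)=O`, differs from compound 2 in one place: (carbamoylmethyl)(methyl)amino in place of (tert-butyl)amino on a carbonyl carbon. For the measured compounds named here, the only measured step touching this position is a step that the two limits leave unreadable from compound 2 to compound 3, and both its ends are limits, so it says nothing about direction or size. Compound 1 is stronger, but it differs from compound 2 in more than one place and cannot be read as a single step. With no readable step at this amide nitrogen, compound 4 is expected to remain weak, and the step that the limit leaves unreadable from compound 2 to compound 4 is estimated as essentially none. Compound 4 is therefore expected at 3000 nM, within 500 nM to 20000 nM.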

Compound 4, half-maximal inhibitory concentration: > 1000 nM
Compound 4 gave a limit, no number; the forecaster's own chance of this, stated with the estimate: 70%; the middle value lies beyond the limit too.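

For the compounds shown here, compound 2 and compound 4 both end at a limit in this assay, so no step between them can be read: the limit of > 1000 nM in this assay, at which 3 of the 4 values shown sit. The compounds shown leave open how strongly compound 2, compound 3 and compound 4 actually inhibit, and whether changing the group on this carbonyl carbon alters that.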